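The source may report more compounds than this note shows. Statements on the series, on what has been measured and on what is new or still open speak of the compounds shown alone.

Measured compounds and their values:

Compound 1, `CS(=O)(=O)Nc1ccc(NC(=O)c2cccc(C(F)(F)F)c2)cc1Cl`, gives > 250000 nM, which is a limit of the assay rather than a number.
Compound 2, `CS(=O)(=O)Nc1ccc(NC(=O)c2cc(C(F)(F)F)cc(C(F)(F)F)c2)cc1Cl`, gives 185000 nM.
Compound 3, `O=C(Nc1ccc(NS(=O)(=O)C(F)(F)F)c(Cl)c1)c1cccc(C(F)(F)F)c1`, gives 210000 nM.

All three were tested in an ADME assay on HEK293 cells (Homo sapiens) for cytotoxicity, read by MTT assay, with a stated time of 48 h; a lower number here means a stronger inhibitor, a higher number a weaker inhibitor. Compound 1 reaches only a limit of the assay, (the limit of > 250000 nM in this assay, at which 1 of the 3 values shown sits), so no number is known for it. Compound 2 differs from compound 1 by trifluoromethyl in place of hydrogen on an aromatic carbon, and this gives an at least 1.3-fold lower number from compound 1 to compound 2 (0.13 log units; that floor lies within the scatter). Compound 3 differs from compound 1 in its core by trifluoromethyl in place of methyl on a sulfonyl sulfur, with an at least 1.1-fold lower number from compound 1 to compound 3 (0.07 log units; that floor lies within the scatter). The values of compound 2 and compound 3 lie close to each other.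

Compound 4, `O=C(Nc1ccc(NS(=O)(=O)C(F)(F)F)c(Cl)c1)c1cc(C(F)(F)F)cc(C(F)(F)F)c1`, is not yet measured in this assay. It differs from compound 3 by trifluoromethyl in place of hydrogen on an aromatic carbon. This is the same change that was made from compound 1 to compound 2, at the same place on the ring.

From that earlier step, an at least 1.3-fold lower number from compound 1 to compound 2 (0.13 log units; that floor lies within the scatter), the change is expected to make only a small difference here, and since compound 3 gives 210000 nM, a value near that number is expected for compound 4. The step expected from compound 3 to compound 4 in this assay is a 1.3-fold lower number from compound 3 to compound 4 (0.12 log units; within the scatter). Compound 4 is thus estimated at 160000 nM, in a range from 90000 nM to 300000 nM.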

Compound 4, half-maximal inhibitory concentration: > 250000 nM
Compound 4 gave a limit, no number (the forecaster's own chance of this, stated with the estimate: 25%); at least 1.5-fold (0.19 log units) between middle value and limit.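

In this assay compound 4 gives > 250000 nM, which is a limit of the assay and not a number. Trifluoromethyl in place of hydrogen on an aromatic carbon gives an at least 1.1-fold higher number from compound 3 to compound 4 (0.07 log units; that floor lies within the scatter), and this step can be neither matched to nor separated from the one made on the core of compound 1, so it does not show whether the change carries over unaltered: the same change on two cores in this assay, an at least 1.3-fold lower number (0.13 log units; that floor lies within the scatter) from compound 1 to compound 2 and an at least 1.1-fold higher number (0.07 log units; that floor lies within the scatter) from compound 3 to compound 4; the limit leaves it open whether they differ In the same way, trifluoromethyl in place of methyl on a sulfonyl sulfur gives an at least 1.3-fold higher number from compound 2 to compound 4 (0.13 log units; that floor lies within the scatter), which shows no measured difference between the two cores but also no proof that the change behaves alike on both: the same change on two cores in this assay, an at least 1.1-fold lower number (0.07 log units; that floor lies within the scatter) from compound 1 to compound 3 and an at least 1.3-fold higher number (0.13 log units; that floor lies within the scatter) from compound 2 to compound 4; the limit leaves it open whether they differ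

The compounds shown leave open how far compound 1 and compound 4 lie past the limit, so the true size of these steps stays unknown: the limit of > 250000 nM in this assay, at which 2 of the 4 values shown sit. They also leave open how the series would read in this assay with a different group on the aromatic ring, such as an amine or a carboxylic acid, or with a longer chain on the sulfonyl sulfur.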